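The source may report more compounds than this note shows. Statements on the series, on what has been measured and on what is new or still open speak of the compounds shown alone.

Compound 1: `COc1ccccc1N1CCN(Cc2ccc(CN3C(=O)c4ccccc4S3(=O)=O)cc2)CC1` gives 10100 nM in an assay on HEK293 cells for displacement of a labelled ligand from 5-hydroxytryptamine receptor 6 (Homo sapiens); on this read-out lower numbers stand for stronger inhibition and higher numbers for weaker inhibition.
Compound 2: `O=C1c2ccccc2S(=O)(=O)N1CCCCCN1CCN(c2ccccc2)CC1` gives 1840 nM in this assay.

Of the two measured compounds, compound 2 stands lowest in this assay, and its gap to compound 1 lies beyond the scatter. Compound 3, `O=C1c2ccccc2S(=O)(=O)N1CCCCCN1CCN(c2ccccn2)CC1`, has not yet been measured. It differs from compound 2 in one place: pyridin-2-yl in place of phenyl on an amine nitrogen in a ring. For the measured compounds named here, no step of this kind has been measured here, so the expectation rests on compound 2 alone. The exchange of one six-membered aromatic ring for another of the same size is expected to give no step beyond the scatter, and a 1.1-fold higher number from compound 2 to compound 3 (0.04 log units; within the scatter) is the step estimated. Compound 3 is therefore estimated at 2000 nM, within a range from 700 nM to 6000 nM.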

Compound 3, inhibition constant: 2630 nM
Beside the measured number, compound 3's estimate is 1.3-fold (0.12 log units) below it, and the stated range covers the measured number.
By their numbers in this assay, from the lowest: compounds 2 and 3 (each within the scatter of the next); then compound 1.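

In this assay, pyridin-2-yl in place of phenyl on this amine nitrogen gives a 1.4-fold higher number from compound 2 to compound 3 (0.16 log units; within the scatter). This position therefore takes a ring with one hetero atom and one hydrogen-bond acceptor without a step beyond the scatter, although this single pair says nothing about other groups here. Nothing available accounts for this result.

Going by these compounds, it remains open whether a pyrimidin-2-yl or benzyl group on the same nitrogen would also stay within the scatter of compound 2. On these data alone, the effect of a chlorine on the phenyl ring of compound 2 also remains open.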